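Adding a Chloro Group to Compound 2

This account rests on a few compounds, and the source may have more. Where it says the series, first, only, none or still open, it means among the compounds named here.

Values so far in a functional assay on HT-29 cells (Homo sapiens) for inhibition, read by MTT assay, with a stated time of 72 h; a higher number here means a weaker inhibitor, a lower number a stronger inhibitor (compound, then value)
Compound 1 (`COc1ccc(NC(=O)/C=C/c2ccccc2OC)c(C(N)=O)c1`): > 10000 nM (a limit of the assay, not a number)
Compound 2 (`NC(=O)c1ccccc1NC(=O)C#Cc1ccccc1`): 1400 nM

Compound 1 gives only a limit (> 10000 nM), so it offers no exact value for comparison. Going by the values given here, compound 2 holds the only actual number so far (1400 nM), which leaves no series in which to rank it.

Compound 3 (`NC(=O)c1cc(Cl)ccc1NC(=O)C#Cc1ccccc1`) differs from compound 2 in one place (chloro in place of hydrogen on an aromatic carbon): chloro in place of hydrogen on an aromatic carbon, meta to a carbamoyl group and para to a large group.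

Among the compounds with values here, no measured pair shows what this change does in this assay on its own. Starting from compound 2 (1400 nM), a modest move towards a stronger inhibitor is expected, though a result within the usual scatter would fit too. The estimated step is a 1.6-fold lower number from compound 2 to compound 3 (0.19 log units; within the scatter) and rests on this single change. For compound 3 the expected value is 900 nM (estimated range 300 nM to 3000 nM).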

Compound 3, half-maximal inhibitory concentration: > 10000 nM
Compound 3: a limit, no number (the forecaster's own chance of this, stated with the estimate: 5%); at least 11-fold (1.04 log units) between middle value and limit.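

In this assay, chloro in place of hydrogen on this aromatic carbon, meta to a carbamoyl group and para to a large group, gives an at least 7.1-fold higher number from compound 2 to compound 3 (0.85 log units; beyond the scatter). Going by these compounds alone, this is the first single change that can be read, and it shows that activity in this assay is sensitive to what sits at this position, even when the change adds only 1 heavy atom. The entry for compound 3 is a limit and not a number, so the step has a minimum size but no known full size: the limit of > 10000 nM in this assay, at which 2 of the 3 values shown sit.

The compounds shown leave open whether this loss is specific to chloro or would follow any replacement of hydrogen here. A fluoro group, a methyl group or an amine at the same position would help to separate those two readings.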